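The source may hold more compounds than are shown below. What is called first, only, known or untested is meant among the compounds shown, and "the series" means these compounds.

Among the compounds with values here, in an ADME assay on the whole organism for pharmacokinetics, with Rattus norvegicus as the target, at a dose of 3 mg/kg by the intravenous route (a lower number here means that more of the compound stays in the plasma, a higher number that more of the compound sits outside the plasma), compound 2 `COC(=O)N[C@H](C(=O)N1CCC[C@H]1C(=O)Nc1ccc([C@@H]2CC[C@@H](c3ccc(NC(=O)[C@@H]4CCCN4C(=O)[C@@H](NC(=O)OC)C(C)C)cc3)N2c2ccc(F)cc2)cc1)C(C)C` gives 2.4 L/kg, the highest of the two numbers known so far, although its gap to compound 1 `COC(=O)N[C@H](C(=O)N1CCC[C@H]1C(=O)Nc1ccc([C@H]2CC[C@H](c3ccc(NC(=O)[C@@H]4CCCN4C(=O)[C@@H](NC(=O)OC)C(C)C)cc3)N2c2ccc(C(F)(F)F)cc2)cc1)C(C)C`, which gives 1.3 L/kg in this assay, is within the scatter. Compound 3 `COC(=O)N[C@H](C(=O)N1CCC[C@H]1C(=O)Nc1ccc([C@@H]2CC[C@@H](c3ccc(NC(=O)[C@@H]4CCCN4C(=O)[C@@H](NC(=O)OC)C(C)C)cc3)N2c2ccc(C(F)(F)F)cc2)cc1)C(C)C` differs from compound 2 by trifluoromethyl in place of fluoro on an aromatic carbon. Within the data shown here, no step of this kind has been measured between compounds, so only a modest shift is expected, and the step of a 1.4-fold lower number from compound 2 to compound 3 (0.15 log units; within the scatter) is estimated to stay within the scatter while leaning lower. Compound 3 is therefore expected to give 1.7 L/kg, within a range from 0.9 L/kg to 3.2 L/kg.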

Compound 3, volume of distribution at steady state in the Rattus norvegicus assay: 8.9 L/kg
The estimate for compound 3 lay 5.2-fold (0.72 log units) below the measured number; the whole stated range lies below it.
By their numbers in the Rattus norvegicus assay, from the lowest: compounds 1 and 2 (each within the scatter of the next); then compound 3.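

At this place on the aromatic ring, para to a large group, trifluoromethyl in place of fluoro brings in the Rattus norvegicus assay a 3.7-fold higher number from compound 2 to compound 3 (0.57 log units; beyond the scatter), while in a physicochemical assay for lipophilicity, read by HPLC, at pH 7.4 (a lower number here means a more polar compound, a higher number a more lipophilic compound), compound 2 gives 4.6 and compound 3 gives 4.8 so that the same change brings only a number 0.20 log units higher from compound 2 to compound 3 (within the scatter). Configuration alone also moves the number, for the Rattus norvegicus assay shows a 6.8-fold higher number from compound 1 to compound 3 (0.84 log units; beyond the scatter), and no change of atoms or bonds can account for that step: the fact that compounds 1 and 3 differ only in the configuration as drawn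

Still open, on these data alone, is whether a chloro or methoxy group at this place would behave like trifluoromethyl. Also open, as far as these compounds go, is whether the fluoro series responds to configuration in the same way.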